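The compounds below may be only part of what the source reports. "The series", "measured", "known", "first", "only" and "open" are said of these compounds alone.

In a functional assay on MCF7 cells (Homo sapiens) for antiproliferative activity, read by MTT assay, with a stated time of 48 h (a lower number here means a stronger inhibitor, a higher number a weaker inhibitor), the measured compounds are:

- compound 1 `O=C(NS(=O)(=O)c1ccc(Br)cc1)c1cncc(Br)c1`: 340 nM
- compound 2 `O=C(NS(=O)(=O)c1ccc(Cl)cc1)c1cncc(Br)c1`: 70 nM
- compound 3 `O=C(NS(=O)(=O)c1ccc(Br)cc1)c1ccc(Cl)nc1`: 9050 nM

Compound 4 `O=C(NS(=O)(=O)c1ccc(Cl)cc1)c1ccc(Cl)nc1` has not yet been measured. Between compound 1 and compound 2 one change is made, (chloro in place of bromo on an aromatic carbon), and it gave a 4.9-fold lower number from compound 1 to compound 2 (0.69 log units; beyond the scatter). Compound 3 carries a different core; how its core differs from that of compound 1 is not broken down here, but compound 3 gives the highest number of the three, well apart from compound 1 and compound 2 in this assay. Compound 4 arises from compound 3 by the same change, (chloro in place of bromo on an aromatic carbon), at the same kind of place. Within the data shown here, the step is expected to be of similar size, a 4.9-fold lower number from compound 3 to compound 4 (0.69 log units; beyond the scatter), because the only comparable measured step is a 4.9-fold lower number from compound 1 to compound 2 (0.69 log units; beyond the scatter). Compound 4 is therefore estimated at about 1850 nM, likely between 700 nM and 5000 nM.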

Compound 4, half-maximal inhibitory concentration: 8070 nM
Compound 4: the middle estimate sits 4.4-fold (0.64 log units) below what was measured; measured number outside the range, above it.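

In this assay, putting chloro in place of bromo on the aromatic carbon gave a 1.1-fold lower number from compound 3 to compound 4 (0.05 log units; within the scatter), so the two cannot be told apart here. The change therefore does not carry over at the same size from the core of compound 1 to the core of compound 3: the same change on two cores in this assay, a 4.9-fold lower number (0.69 log units; beyond the scatter) from compound 1 to compound 2 and a 1.1-fold lower number (0.05 log units; within the scatter) from compound 3 to compound 4, 4.3-fold (0.64 log units) apart, beyond the scatter of two such steps This shows that the size of the step differed between these two cores, but it does not show why, and two pairs give no rule for any further core.

On these data alone, it remains open how an amine, a methoxy group or a carboxylic acid in that place would behave on either core. As far as these compounds go, it also remains open which of the two step sizes, if either, another core would follow.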